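Swapping a triazole for a benzamide on a weak cytotoxic series

This account rests on a few compounds, and the source may have more. Where it says the series, first, only, none or still open, it means among the compounds named here.

Compound 2 `NC(=O)c1cn(Cc2nnc(-c3cc(S(N)(=O)=O)c(SCc4ccccc4)cc3Cl)o2)nn1` gives 75000 nM in a functional assay on HeLa cells (Homo sapiens) for cytotoxicity, read by MTT assay, with a stated time of 72 h; a higher number here means a weaker inhibitor, a lower number a stronger inhibitor.
Compound 1 `NS(=O)(=O)c1cc(-c2nnc(CN3CCN(c4ccccc4)CC3)o2)c(Cl)cc1SCc1ccccc1` gives 100000 nM in this assay.
Compound 3 `COc1ccc(-c2cn(Cc3nnc(-c4cc(S(N)(=O)=O)c(SCc5ccccc5)cc4Cl)o3)nn2)cc1` gives 68000 nM in this assay.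

All three compounds share one core and differ only in the group carried on the saturated chain carbon bound to an aromatic carbon. Compound 2 sits within the scatter of both compound 1 and compound 3: the step of a 1.3-fold lower number from compound 1 to compound 2 (0.12 log units; within the scatter) and the step of a 1.1-fold lower number from compound 2 to compound 3 (0.04 log units; within the scatter) are both too small to count as real change. Compound 4 `NS(=O)(=O)c1cc(-c2nnc(CNC(=O)c3ccccc3)o2)c(Cl)cc1SCc1ccccc1` carries the change (benzamido in place of 4-carbamoyl-1H-1,2,3-triazol-1-yl on a saturated chain carbon bound to an aromatic carbon). Since the two measured swaps at this same position moved nothing beyond the scatter, no real step is expected from compound 2 to compound 4 either, a 1.1-fold higher number from compound 2 to compound 4 (0.03 log units; within the scatter). Compound 4 is therefore estimated at 80000 nM, with a range from 30000 nM to 200000 nM.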

Compound 4, half-maximal inhibitory concentration: 105000 nM
Estimate against measurement, compound 4: 1.3-fold (0.12 log units) below; the range from low to high includes it.
By their numbers in this assay, from the lowest: compounds 3, 2, 1 and 4 (each within the scatter of the next).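

Moving to benzamido on a saturated chain carbon bound to an aromatic carbon brings no real change in this assay: the data show a 1.4-fold higher number from compound 2 to compound 4 (0.15 log units; within the scatter) and a 1.1-fold higher number from compound 1 to compound 4 (0.02 log units; within the scatter) and neither step counts as a shift. The earlier compounds shown here had only triazole and piperazine groups here, whereas this amide link with its six-membered aromatic ring of carbon only, and fewer hydrogen-bond acceptors than the triazole it replaces, reads the same. On these data alone, whether an amine or a carboxylic acid on this carbon would move the number stays open. Nothing on hand explains why these swaps leave the number in place.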